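The source may report more compounds than this note shows. Statements on the series, on what has been measured and on what is new or still open speak of the compounds shown alone.

Three compounds have been measured in an ADME assay on the whole organism (plasma) for pharmacokinetics, with Rattus norvegicus as the target, with a stated time of 6 h, at a dose of 10 mg/kg by the oral route; on this read-out higher numbers stand for higher exposure at the dose given and lower numbers for lower exposure:
Compound 1, `Cc1nc(NC(C)(C)C)nc(N[C@@H]2C[C@H](CO)[C@@H](O)[C@H]2O)c1-c1nc2ccccc2s1`, gives 2220 ng.h/mL.
Compound 2, `Cc1nc(NCC(C)C)nc(N[C@@H]2C[C@H](CO)[C@@H](O)[C@H]2O)c1-c1nc2ccccc2s1`, gives 1020 ng.h/mL.
Compound 3, `Cc1nc(Nc2ccccc2)nc(N[C@@H]2C[C@H](CO)[C@@H](O)[C@H]2O)c1-c1nc2ccccc2s1`, gives 742 ng.h/mL.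

All three share the same core and differ only in the group carried on a nitrogen on an aromatic ring. Compound 2 stands second highest of these three numbers: compound 1 is above it, a 2.2-fold lower number from compound 1 to compound 2 (0.34 log units; beyond the scatter), while compound 3 sits close to it, a 1.4-fold lower number from compound 2 to compound 3 (0.14 log units; within the scatter), a gap too small to count as a real difference.

Compound 4, `Cc1nc(NCc2ccccc2)nc(N[C@@H]2C[C@H](CO)[C@@H](O)[C@H]2O)c1-c1nc2ccccc2s1`, has not yet been measured. It differs from compound 2 in one place: phenyl in place of isopropyl on a saturated chain carbon bound to a nitrogen on an aromatic ring. Among the compounds with values here, two measured steps bear on this. Swapping isobutyl for phenyl on the nitrogen gave a 1.4-fold lower number from compound 2 to compound 3 (0.14 log units; within the scatter), and swapping tert-butyl for phenyl gave a 3.0-fold lower number from compound 1 to compound 3 (0.48 log units; beyond the scatter); in both, bringing in a phenyl moved the number downward or left it flat. Compound 4 keeps one chain carbon between the nitrogen and the phenyl, so the expectation is a small drop or none beyond the scatter, a 1.3-fold lower number from compound 2 to compound 4 (0.11 log units; within the scatter). Compound 4 is therefore estimated at 800 ng.h/mL, with a range from 350 ng.h/mL to 1800 ng.h/mL.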

Compound 4, area under the concentration-time curve: 1050 ng.h/mL
Estimate against measurement, compound 4: 1.3-fold (0.12 log units) below, and the stated range covers the measured number.
By their numbers in this assay, from the lowest: compounds 3, 2 and 4 (each within the scatter of the next); then compound 1.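

In this assay the larger group, with its six-membered aromatic ring of carbon only, is accepted on the saturated chain carbon bound to the nitrogen without a readable change in exposure: phenyl in place of isopropyl gives (a 1.0-fold higher number from compound 2 to compound 4 (0.01 log units; within the scatter)). Benzyl in place of phenyl on the nitrogen also makes no readable difference (a 1.4-fold higher number from compound 3 to compound 4 (0.15 log units; within the scatter)), so among these four compounds only compound 1 stands apart, and benzyl in place of tert-butyl still gives a step beyond the scatter (a 2.1-fold lower number from compound 1 to compound 4 (0.33 log units; beyond the scatter)). Nothing measured here explains why exposure holds level across compound 2, compound 3 and compound 4, or why compound 1 stands apart.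

Going by these compounds, it remains open whether a longer chain, such as phenethyl on the nitrogen, or a benzyl ring carrying a methoxy group or an amine would stay level with compound 4 or shift exposure beyond the scatter. On these data alone, a single exposure number also cannot separate how much of each compound is absorbed from how quickly it is cleared, so what lies behind the higher number of compound 1 is still unknown.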